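Sulfonamide tolerance in HepG2 cells: ethyl on the aryl ring

The compounds below may be only part of what the source reports. "The series", "measured", "known", "first", "only" and "open" are said of these compounds alone.

Measured so far in an ADME assay on HepG2 2.2.15 cells (Homo sapiens) for cytotoxicity; a higher number here means that more compound is tolerated, a lower number that less compound is tolerated:
- compound 1 `O=C(Nc1ncc(C(Oc2ccc3cc(Br)ccc3c2)c2ccc(Cl)cc2)s1)c1ccc(F)cc1F` gives "not toxic" (no number reported)
- compound 2 `O=S(=O)(Nc1ncc(C(Oc2ccc3cc(Br)ccc3c2)c2ccc(Cl)cc2)s1)c1ccccc1` gives > 50000 nM

Compound 1 carries an amide at the shared core and is reported only in words, with no number. Compound 2, the phenylsulfonyl analogue, reaches only a limit of this assay, > 50000 nM; it sits at the limit of > 50000 nM in this assay, at which 1 of the 2 values shown sits. Within the data shown here, compound 2 therefore has no single number, and no step between measured compounds can be computed.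

Compound 3 `CCc1ccc(S(=O)(=O)Nc2ncc(C(Oc3ccc4cc(Br)ccc4c3)c3ccc(Cl)cc3)s2)cc1` differs from compound 2 by ethyl in place of hydrogen on an aromatic carbon. Among the measured compounds shown here, with no measured step to lean on, the expectation rests on compound 2 alone, and the change is expected to stay within the usual scatter, if anything leaning toward slightly less tolerance. The step from compound 2 to compound 3 is estimated at an at least 1.1-fold lower number from compound 2 to compound 3 (0.04 log units; that floor lies within the scatter). Compound 3 is thus expected near 45000 nM, between 15000 nM and 100000 nM, with a fair chance that this assay again reports only a limit.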

Compound 3, half-maximal cytotoxic concentration: > 50000 nM
Compound 3: a limit, no number; the forecaster's own chance of this, stated with the estimate: 60%; middle value at least 1.1-fold (0.04 log units) from the limit.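

In this assay, compound 2 and compound 3 each end at a limit rather than a number, so no step between them can be read: the limit of > 50000 nM in this assay, at which 2 of the 3 values shown sit.

The compounds shown leave open whether ethyl in place of hydrogen on the aromatic carbon changes tolerance at all.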